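This account rests on a few compounds, and the source may have more. Where it says the series, first, only, none or still open, it means among the compounds named here.

Three compounds have been measured in a functional assay on SNU-638 cells (Homo sapiens) for cytotoxicity, read by sulforhodamine B assay, with a stated time of 72 h; on this read-out higher numbers stand for weaker inhibition and lower numbers for stronger inhibition:

Compound 1 `CCS(=O)(=O)Nc1cc(-c2ccc3ncnc(Nc4ccc(F)cc4F)c3c2)cnc1OC`: 2050 nM
Compound 2 `CCS(=O)(=O)Nc1cc(-c2ccc3ncnc(Nc4ccc(OC)cc4)c3c2)cnc1OC`: 3970 nM
Compound 3 `CCS(=O)(=O)Nc1cc(-c2ccc3ncnc(Nc4ccc(OC)c(OC)c4)c3c2)cnc1OC`: 1680 nM

Compound 1 has the second highest of these three numbers; its nearest neighbour differs by a 1.2-fold lower number from compound 1 to compound 3 (0.09 log units; within the scatter) and its furthest by a 1.9-fold higher number from compound 1 to compound 2 (0.29 log units; within the scatter). Compound 4 `CCS(=O)(=O)Nc1cc(-c2ccc3ncnc(Nc4ccc(F)c(C(=O)OC)c4)c3c2)cnc1OC` has not been measured. It differs from compound 1 by 4-fluoro-3-(methoxycarbonyl)phenyl in place of 2,4-difluorophenyl on a nitrogen on an aromatic ring. The two measured steps that swap the ring on that same nitrogen both stayed within the scatter, while a 2.4-fold lower number from compound 2 to compound 3 (0.37 log units; beyond the scatter) shows that a single added group on that ring can shift the number modestly. In this assay the change to compound 4 is therefore expected to be small, at most a 1.0-fold lower number from compound 1 to compound 4 (0.01 log units; within the scatter). Compound 4 is thus estimated at 2000 nM, between 800 nM and 5000 nM.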

Compound 4, half-maximal inhibitory concentration: 2540 nM
Compound 4: the middle estimate sits 1.3-fold (0.10 log units) below what was measured; low and high end bracket the measured number.
By their numbers in this assay, from the lowest: compounds 3, 1, 4 and 2 (each within the scatter of the next, the first and the last beyond it).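

In this assay, within the data shown here, the nitrogen on an aromatic ring tolerates 4-fluoro-3-(methoxycarbonyl)phenyl, a ring with a carbonyl-bearing ester that none of the earlier compounds has, and the number stays within the scatter of all three: a 1.2-fold higher number from compound 1 to compound 4 (0.09 log units; within the scatter), a 1.5-fold higher number from compound 3 to compound 4 (0.18 log units; within the scatter) and a 1.6-fold lower number from compound 2 to compound 4 (0.19 log units; within the scatter). Nothing available explains why the number moves so little.

Still open, on these data alone, is whether a carboxylic acid, an amine or a longer ester chain in place of the methoxycarbonyl would keep the number in this range. Also open, as far as these compounds go, is whether any ring at this position can bring it far lower.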